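Amide-region variation in a series of EP1 ligands

The compounds below may be only part of what the source reports. "The series", "measured", "known", "first", "only" and "open" are said of these compounds alone.

Measured compounds:
Compound 1, `Cc1cc(C(=O)Nc2c(F)cccc2F)nn1Cc1cc(Cl)ccc1OCc1ccccc1`, 10 nM in an assay on CHO-K1 cells for displacement of a labelled ligand from prostaglandin E2 receptor EP1 subtype (Homo sapiens); a higher number here means a weaker inhibitor, a lower number a stronger inhibitor.
Compound 2, `Cc1cc(C(=O)NCc2ccccn2)nn1Cc1cc(Cl)ccc1OCc1ccccc1`, 25.1 nM in this assay.
Compound 3, `Cc1cc(NC(=O)CC(C)(C)C)nn1Cc1cc(Cl)ccc1OCc1ccccc1`, 10 nM in this assay.

Compound 3 stands level with compound 1 at the digits given, and together these two give the lowest numbers of the three; compound 2 sits apart, the step of a 2.5-fold lower number from compound 2 to compound 3 (0.40 log units; beyond the scatter). The step of no change at the digits printed from compound 1 to compound 3 (within the scatter) shows that turning the carbamoyl group round into an acylamino group on the shared core costs nothing that can be seen above the scatter. Within the data shown here, the step of a 2.5-fold higher number from compound 1 to compound 2 (0.40 log units; beyond the scatter) is the only change here that moves the number clearly.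

Compound 4, `Cc1cc(NC(=O)CC2CCCCC2)nn1Cc1cc(Cl)ccc1OCc1ccccc1`, keeps the acylamino arrangement of compound 3 and changes only the group on the chain: cyclohexyl in place of tert-butyl on a saturated chain carbon bound to a carbonyl carbon. Among the measured compounds shown here, no measured pair tests this change directly. The two steps that touch compound 3 both concern the amide orientation, not the saturated group beyond the carbonyl; the nearer of them, no change at the digits printed from compound 1 to compound 3 (within the scatter), lies within the scatter. With nothing in hand pointing either way, the expectation for compound 4 in this assay is a step of no change at the digits printed from compound 3 to compound 4 (within the scatter), not beyond the scatter. Compound 4 is estimated at 10 nM, with a range of 4 nM to 25 nM.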

Compound 4, half-maximal inhibitory concentration: 6.31 nM
Beside the measured number, compound 4's estimate is 1.6-fold (0.20 log units) above it; low and high end bracket the measured number.
By their numbers in this assay, from the lowest: compounds 4, 1 and 3 (each within the scatter of the next); then compound 2.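

Cyclohexyl in place of tert-butyl on a saturated chain carbon bound to a carbonyl carbon is now tested directly in this assay and gives a 1.6-fold lower number from compound 3 to compound 4 (0.20 log units; within the scatter), so going from 4 heavy atoms with no ring to 6 heavy atoms in one six-membered non-aromatic ring leaves the number within the scatter. The wider comparisons place compound 4 with the lower group: a 1.6-fold lower number from compound 1 to compound 4 (0.20 log units; within the scatter) is also within the scatter, whereas a 4.0-fold lower number from compound 2 to compound 4 (0.60 log units; beyond the scatter) is beyond it and leaves compound 2 apart from compound 4 by more than compound 3 alone had shown. No measurement available here explains why this place accepts both groups.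

Going by these compounds, both groups compared at this place consist of carbon only and have no hydrogen-bond donors or acceptors, so it remains open how the number would respond to an amine or a carboxylic acid on the chain. A phenyl ring in place of cyclohexyl, or a longer chain between the ring and the carbonyl, would show whether the number stays level beyond these two saturated groups.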